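The compounds below may be only part of what the source reports. "The series", "measured", "known", "first", "only" and "open" are said of these compounds alone.

Measured compounds:
- compound 1 `Cc1ccc(NC(=S)NC(=O)c2ccc(OCc3ccccc3F)cc2)cc1-c1nc2ccccc2[nH]1` gives 2420 nM
- compound 2 `O=C(NC(=S)Nc1ccc(Cl)c(-c2nc3ccccc3[nH]2)c1)c1ccc(OCc2ccc(Cl)c(Cl)c2)cc1` gives 4600 nM
- compound 3 `Cc1ccc(NC(=O)NC(=O)c2ccc(OCc3ccc(C(F)(F)F)cc3)cc2)cc1-c1nc2ccccc2[nH]1` gives 16800 nM

All three numbers come from a functional assay on MNK45 cells (Homo sapiens) for inhibition, read by MTT assay, with a stated time of 48 h; on this read-out higher numbers stand for weaker inhibition and lower numbers for stronger inhibition. Among them compound 3 stands at the highest number, which here means the weakest inhibition: compound 2 sits well below it and compound 1 further still, and both of those gaps are beyond the ordinary scatter of this assay.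

Compound 4 `Cc1ccc(NC(=O)NC(=O)c2ccc(OCc3cccc(Cl)c3Cl)cc2)cc1-c1nc2ccccc2[nH]1` keeps everything in compound 3 except the outer ring at one end of the molecule. There, the change is 2,3-dichlorophenyl in place of 4-(trifluoromethyl)phenyl on a saturated chain carbon bound to an oxygen on an aromatic ring.

Going by the values given here, no measured pair in this set differs in that one place only, so no step of this kind has been seen directly. Compound 2 carries a dichlorobenzyl group too, but it also differs from compound 3 elsewhere, so its number cannot be credited to the benzyl ring alone. With nothing more to go on, the expected step from compound 3 to compound 4 in this assay is a 1.5-fold lower number from compound 3 to compound 4 (0.18 log units; within the scatter), which is a small move toward stronger inhibition that may well lie within the scatter. Compound 4 is therefore estimated at 11000 nM, with a plausible range from 3500 nM to 35000 nM.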

Compound 4, half-maximal inhibitory concentration: 87000 nM
Compound 4: the middle estimate sits 7.9-fold (0.90 log units) below what was measured, and the stated range ends below it.
By their numbers in this assay, from the lowest: compounds 1 and 2 (each within the scatter of the next); then compound 3; then compound 4.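

In this assay the outer ring on a saturated chain carbon bound to an oxygen on an aromatic ring proves not to be a silent spot: with everything else held the same, putting 2,3-dichlorophenyl in place of 4-(trifluoromethyl)phenyl weakens inhibition (a 5.2-fold higher number from compound 3 to compound 4 (0.71 log units; beyond the scatter)). Going by these compounds alone, this is the first direct reading of this position, and the step lies beyond the scatter, so the identity of this ring matters for the number. Nothing available explains why the number rises.

On these data alone, whether the loss follows from removing the trifluoromethyl group or from adding the two chlorines stays open. A plain phenyl ring, or a ring carrying an amine or a carboxylic acid, would help separate these two readings and show how much change this position accepts.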